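Swapping the amide-bound ring system of compound 1

This account rests on a few compounds, and the source may have more. Where it says the series, first, only, none or still open, it means among the compounds named here.

Compound 1 `O=C(NCc1ccc(S(=O)(=O)c2ccccc2)cc1)c1cc2ccncc2s1` gives 21% in an ADME assay on microsomes from liver (Mus musculus) for metabolic stability, read by LC-MS, with a stated time of 30 min, tested at 1 uM (a higher number here means that more of the compound is left, a lower number that less of the compound is left), the second highest of the three numbers shown. Compound 2 `O=C(NCc1ccc(S(=O)(=O)c2cc(F)cc(F)c2)cc1)c1cc2ccncc2o1` gives 12%, within the scatter of compound 1, and compound 3 `O=C(NCc1ccc(S(=O)(=O)c2cccc(C(F)(F)F)c2)cc1)c1cc2ccncc2s1` gives 35%; the step of a number 14 percentage points higher from compound 1 to compound 3 (beyond the scatter) is the only one measured, and it involves a different part of the molecule.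

Compound 4 `O=C(NCc1ccc(S(=O)(=O)c2ccccc2)cc1)c1cnc2nccn2c1` differs from compound 1 by a group of 9 heavy atoms (6 carbon, 3 nitrogen; one five-membered aromatic ring with 2 hetero atoms, one six-membered aromatic ring with 2 hetero atoms) in place of a group of 9 heavy atoms (7 carbon, 1 nitrogen, 1 sulfur; one five-membered aromatic ring with 1 hetero atom, one six-membered aromatic ring with 1 hetero atom), on a carbonyl carbon. Going by the values given here, no measured step touches the group on the carbonyl carbon, so nothing here tells how large a step to expect in this assay, in either direction; a change of no more than the scatter is the default expectation. The estimate for compound 4 is therefore 28%, spanning 12% to 50%, a step of a number 7 percentage points higher from compound 1 to compound 4 (within the scatter).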

Compound 4, percent of the compound remaining: 30%
The estimate for compound 4 lay 2 percentage points below the measured number, within the range that was stated.
By their numbers in this assay, from the lowest: compounds 2, 1, 4 and 3 (each within the scatter of the next, the first and the last beyond it).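

Putting a group of 9 heavy atoms (6 carbon, 3 nitrogen) on the carbonyl carbon in place of the sulfur-containing ring system gives a number 9 percentage points higher from compound 1 to compound 4 (within the scatter) in this assay. Going by these compounds alone, this is the first measured change at this position, and it shows that the sulfur-containing group can be exchanged here without a difference beyond the scatter. Nothing available explains this result. Going by these compounds, it remains open whether the same exchange would behave alike on compound 3, with its trifluoromethyl group. Also open, on these data alone, is what a much simpler group on the carbonyl carbon, such as a methyl or a plain phenyl ring, would give.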